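Swapping trifluoromethyl for chloro on a diaryl urea

The source may report more compounds than this note shows. Statements on the series, on what has been measured and on what is new or still open speak of the compounds shown alone.

Measured compounds:
- compound 1, `COc1cc2cc(Oc3ccc(NC(=O)Nc4cccc(C(F)(F)F)c4)cc3)c(C)nc2cc1OC`, 1130 nM
- compound 2, `COc1cc2cc(Oc3ccc(NC(=O)Nc4ccc(Cl)c(C(F)(F)F)c4)cc3)c(C)nc2cc1OC`, 681 nM

Both compounds share a core and were tested in a functional assay on MDA-MB-231 cells (Homo sapiens) for inhibition, read by sulforhodamine B assay, with a stated time of 48 h; on this read-out lower numbers stand for stronger inhibition of growth and higher numbers for weaker inhibition of growth. Compound 2 gives the lower of the two numbers, but the gap to compound 1, a 1.7-fold lower number from compound 1 to compound 2 (0.22 log units; within the scatter), is no larger than repeat measurements of this kind usually differ, so neither compound can be called the more potent.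

Compound 3, `COc1cc2cc(Oc3ccc(NC(=O)Nc4ccc(Cl)c(Cl)c4)cc3)c(C)nc2cc1OC`, has not been measured. It differs from compound 2 in one place: chloro in place of trifluoromethyl on an aromatic carbon.

Among the measured compounds shown here, the only measured step, from compound 1 to compound 2, concerns adding a chloro group next to an unchanged trifluoromethyl, and it stayed within the scatter. For the measured compounds named here, no measured pair shows what replacing the trifluoromethyl itself by chloro does, so there is no direct precedent. Going by the values given here, with the one step available being small, the expected change for compound 3 in this assay is a 1.3-fold higher number from compound 2 to compound 3 (0.12 log units; within the scatter), which is no more than the scatter. Compound 3 is therefore estimated at 900 nM, with a plausible range from 400 nM to 2200 nM.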

Compound 3, concentration for 50% growth inhibition: 2460 nM
The estimate for compound 3 lay 2.7-fold (0.44 log units) below the measured number; measured number above the stated range.
By their numbers in this assay, from the lowest: compounds 2 and 1 (each within the scatter of the next); then compound 3.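

In this assay, chloro in place of trifluoromethyl on this aromatic carbon, ortho to a chloro group, gives a 3.6-fold higher number from compound 2 to compound 3 (0.56 log units; beyond the scatter), so the group at this position matters, and here trifluoromethyl goes with stronger inhibition of growth than chloro. The earlier step added a chloro group while the trifluoromethyl stayed in place and remained within the scatter, whereas 3,4-dichlorophenyl in place of 3-(trifluoromethyl)phenyl gives a 2.2-fold higher number from compound 1 to compound 3 (0.34 log units; beyond the scatter), so the compound with chloro at this position also falls behind the one carrying trifluoromethyl and no added chloro. Nothing available here accounts for why the number rises with this change.

The compounds shown leave open where other groups at this position, such as a nitrile, a bromo or a methyl group, would fall relative to trifluoromethyl and chloro. They also leave open whether the same swap would give a step of similar size without the ortho chloro group, which would need a 3-chlorophenyl compound to set against compound 1.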